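This account rests on a few compounds, and the source may have more. Where it says the series, first, only, none or still open, it means among the compounds named here.

Compound 1 `O=C(c1cc(-n2cc(-c3cccc(Cl)c3)nn2)ccc1O)N1CCCCC1` and compound 2 `O=C(c1cc(-n2cc(-c3cc(F)cc(F)c3)nn2)ccc1O)N1CCCCC1` share one core, while compound 3 `CCCNC(=O)c1ccc(-n2cc(-c3cccc(Cl)c3)nn2)cc1O` and compound 4 `CCCNC(=O)c1ccc(-n2cc(-c3cc(F)cc(F)c3)nn2)cc1O` share another; the difference between the two cores is not broken down here. In a functional assay on RAW264.7 cells (Mus musculus) for inhibition, read by Griess assay, with a stated time of 20 h (a lower number here means a stronger inhibitor, a higher number a weaker inhibitor), compound 1 gives only a limit, > 20000 nM. In this assay compound 2 likewise gives only a limit, > 20000 nM. The change between them, (3,5-difluorophenyl in place of 3-chlorophenyl on an aromatic carbon), accordingly makes a step that the two limits leave unreadable from compound 1 to compound 2. In this assay compound 3 also reaches only a limit, > 20000 nM. Every measured value here sits at the limit of > 20000 nM in this assay, at which 3 of the 3 values shown sit. Compound 4 arises from compound 3 by the same change, (3,5-difluorophenyl in place of 3-chlorophenyl on an aromatic carbon). The step from compound 3 to compound 4 is expected to be a step that the limit leaves unreadable from compound 3 to compound 4, an expectation resting on compound 1 and compound 3 both sitting at the limit of > 20000 nM in this assay, at which 3 of the 3 values shown sit. Compound 4 is therefore estimated at 30000 nM, with a likely range from 10000 nM to 100000 nM.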

Compound 4, half-maximal inhibitory concentration: > 20000 nM
Compound 4: no number, only a limit; the forecaster's own chance of this, stated with the estimate: 85%; the middle value lies beyond the limit too.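

Going by these compounds alone, compound 3 and compound 4 both give only a limit in this assay, so no step between them can be read. The compounds shown leave open how strongly any of them inhibits, and whether 3,5-difluorophenyl in place of 3-chlorophenyl changes this at all.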